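Bromo to chloro on the indane ring of a urea

The source may report more compounds than this note shows. Statements on the series, on what has been measured and on what is new or still open speak of the compounds shown alone.

Measured compounds:
compound 1, `CC(C)(C)c1cccc2c1CCC2NC(=O)Nc1cccc2[nH]ncc12`, 14 nM
compound 2, `O=C(Nc1cccc2[nH]ncc12)NC1CCc2cc(Br)ccc21`, 9 nM

Both compounds were tested in an assay on isolated protein for inhibition of transient receptor potential cation channel subfamily V member 1 (Homo sapiens), read by calcium flux; a higher number here means a weaker inhibitor, a lower number a stronger inhibitor. In this assay compound 1 gives 14 nM, and compound 2 gives 9 nM. The gap between the two lies within the scatter, so compound 2 cannot be set apart from compound 1 on these numbers; it simply stands at one end of a pair that reads alike.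

Compound 3, `O=C(Nc1cccc2[nH]ncc12)NC1CCc2cc(Cl)ccc21`, has not yet been measured. It differs from compound 2 by chloro in place of bromo on an aromatic carbon. For the measured compounds named here, no measured pair in this set shows what such a halogen swap does in this assay, so the expectation rests on the size of the change alone. One heavy atom is exchanged for another of the same kind at the same place, and no donor, acceptor or charge is gained or lost. The step from compound 2 to compound 3 is therefore expected to be small, a 1.4-fold higher number from compound 2 to compound 3 (0.16 log units; within the scatter), with no direction that would clearly exceed the scatter. For compound 3 the estimated value in this assay is 13 nM, within a range from 5 nM to 35 nM.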

Compound 3, half-maximal inhibitory concentration: 10 nM
The estimate for compound 3 lay 1.3-fold (0.11 log units) above the measured number, and the stated range covers the measured number.
By their numbers in this assay, from the lowest: compounds 2, 3 and 1 (each within the scatter of the next).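

The exchange of bromo for chloro on an aromatic carbon of the six-membered aromatic ring gives, in this assay, a 1.1-fold higher number from compound 2 to compound 3 (0.05 log units; within the scatter), so the two halogens cannot be told apart at this position. For the compounds shown here, this is the first pair in the set that differs in one place, and thus the first direct reading of a single change at this position; the earlier compounds differed too widely to offer one. No supporting measurement bears on why the two halogens read alike.

The compounds shown carry only these two halogens at this aromatic carbon, so they leave open whether a halogen is needed there at all. What plain hydrogen, a methoxy group, an amine or a carboxylic acid would do in that place remains an open question.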